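This account rests on a few compounds, and the source may have more. Where it says the series, first, only, none or still open, it means among the compounds named here.

Measured in a functional assay on PC-9 cells (Homo sapiens) for inhibition, read by MTT assay, with a stated time of 72 h; a lower number here means a stronger inhibitor, a higher number a weaker inhibitor:
- Compound 1 `Cc1cc(Nc2cc(-c3ccccc3)[nH]n2)n2nc(SCCc3ccccc3)nc2n1`: 4930 nM
- Compound 2 `Cc1cc(Nc2cc(-c3ccccc3)[nH]n2)n2nc(SCc3ccc([N+](=O)[O-])cc3)nc2n1`: 7980 nM
- Compound 3 `Cc1cc(Nc2cc(-c3ccccc3)[nH]n2)n2nc(SCC3CCCCC3)nc2n1`: > 50000 nM

Compound 3 is the weakest of the three in this assay. For compound 3, > 50000 nM is a limit of the assay and not a number.

Compound 4 `Cc1cc(Nc2cc(-c3ccccc3)[nH]n2)n2nc(SCC(=O)c3ccccc3)nc2n1` keeps the shared core but has benzoyl in place of cyclohexyl on a saturated chain carbon bound to a sulfur. It therefore regains a six-membered aromatic ring.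

Within the data shown here, two measured steps bear on this change, each replacing an aromatic group with cyclohexyl: an at least 10-fold higher number from compound 1 to compound 3 (1.00 log units; beyond the scatter) and an at least 6.2-fold higher number from compound 2 to compound 3 (0.79 log units; beyond the scatter). Both lie beyond the scatter. A third, a 1.6-fold higher number from compound 1 to compound 2 (0.21 log units; within the scatter), lies within it, so the two aromatic compounds are not told apart. None of the three compounds goes against this picture, although none carries the carbonyl of benzoyl.

A step of similar size towards a lower number is therefore expected, reversing those two steps. The expected change is an at least 6.2-fold lower number from compound 3 to compound 4 (0.79 log units; beyond the scatter). The estimated value for compound 4 is 8000 nM, with an expected range from 2500 nM to 30000 nM.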

Compound 4, half-maximal inhibitory concentration: 4450 nM
For compound 4 the middle estimate is 1.8-fold (0.25 log units) above the measured one; the measured number falls inside the stated range.
By their numbers in this assay, from the lowest: compounds 4, 1 and 2 (each within the scatter of the next). At a limit, above all of these: compound 3.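

In this assay, benzoyl on a saturated chain carbon bound to a sulfur brings back a measurable value, so the carbonyl is tolerated here (an at least 11-fold lower number from compound 3 to compound 4 (1.05 log units; beyond the scatter)). That step is only a bound, and compound 3 stands at a limit of the assay and not at a number: the limit of > 50000 nM in this assay, at which 1 of the 4 values shown sits. Benzoyl also cannot be told apart from the other two aromatic groups (both a 1.8-fold lower number from compound 2 to compound 4 (0.25 log units; within the scatter) and a 1.1-fold lower number from compound 1 to compound 4 (0.04 log units; within the scatter) lie within the scatter), so among the four compounds, cyclohexyl, the only group without an aromatic ring, stands apart, and no compound goes against this.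

Cyclohexyl is the sole non-aromatic group shown, so it remains open whether the aromatic ring itself is what counts. From the compounds shown here alone, it is also open how an amine, a carboxylic acid or a longer chain would read at this position.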